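Aryl sulfone series: chlorophenyl swap, microsomal clearance

The source may report more compounds than this note shows. Statements on the series, on what has been measured and on what is new or still open speak of the compounds shown alone.

Compound 3 `COc1cccc(-c2c(S(=O)(=O)c3ccc(C)c(C)c3)cnc3cc(F)ccc23)c1` gives 8.78 mL/min in an ADME assay on microsomes from liver (Homo sapiens) for metabolic stability, tested at 2.5 uM (a higher number here means faster removal of the compound, a lower number slower removal), the second highest of the three numbers. Compound 1 `Cc1ccc(S(=O)(=O)c2cnc3cc(F)ccc3c2-c2ccc(F)cc2)cc1C` gives 9.25 mL/min, and the step of a 1.1-fold lower number from compound 1 to compound 3 (0.02 log units; within the scatter) lies within the scatter. Compound 2 `O=S(=O)(c1ccc(F)c(F)c1)c1cnc2cc(F)ccc2c1-c1ccc(Cl)cc1` gives 0.01 mL/min, far lower than compound 3, but it differs from compound 3 in two places, so only the two values can be set side by side. Compound 4 `Cc1ccc(S(=O)(=O)c2cnc3cc(F)ccc3c2-c2ccc(Cl)cc2)cc1C` differs from compound 3 as follows: 4-chlorophenyl in place of 3-methoxyphenyl on an aromatic carbon. Among the compounds with values here, the one measured step, a 1.1-fold lower number from compound 1 to compound 3 (0.02 log units; within the scatter), is the only step on the same position and was flat. For compound 4, a step of a 1.5-fold lower number from compound 3 to compound 4 (0.17 log units; within the scatter) is therefore expected. Compound 4 is estimated at 6 mL/min, within 1.5 mL/min to 12 mL/min.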

Compound 4, intrinsic clearance in a liver preparation (reported as CLH), per the amount of preparation that the assay uses: 7.88 mL/min
Beside the measured number, compound 4's estimate is 1.3-fold (0.12 log units) below it, and the stated range covers the measured number.
By their numbers in this assay, from the lowest: compound 2; then compounds 4, 3 and 1 (each within the scatter of the next).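

In this assay, the aryl group at this place tolerates the swap to 4-chlorophenyl, with both steps flat (a 1.1-fold lower number from compound 3 to compound 4 (0.05 log units; within the scatter); a 1.2-fold lower number from compound 1 to compound 4 (0.07 log units; within the scatter)). The large change lies instead on the sulfonyl sulfur, where 3,4-dimethylphenyl in place of 3,4-difluorophenyl gives a wide step (a 790-fold higher number from compound 2 to compound 4 (2.90 log units; beyond the scatter)), so 4-chlorophenyl alone does not accompany the low number of compound 2. Nothing at hand accounts for the size of that step. Still open, going by these compounds, is whether one fluoro or both go with that step, and how an amine or a carboxylic acid on the aryl group would read.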